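The source may hold more compounds than are shown below. What is called first, only, known or untested is meant among the compounds shown, and "the series" means these compounds.

Working notes on the series in a functional assay on A2780 cells (Homo sapiens) for inhibition; a lower number here means a stronger inhibitor, a higher number a weaker inhibitor. Within the data shown here, compound 1 (`CC(C(=O)Nc1cc(C2CC2)[nH]n1)c1ccc(N2C(=O)CCC2C)cc1`) gives 6400 nM, the higher of the two numbers so far. Compound 2 (`C[C@H](C(=O)Nc1cc(C2CC2)[nH]n1)c1ccc(N2CCCC2)cc1`) gives 220 nM, and the gap between the two lies beyond the scatter. Compound 3 (`CC(C(=O)Nc1cc(C2CC2)[nH]n1)c1ccc(N2C(=O)CCC2c2ccccc2)cc1`) is not yet measured. It has phenyl in place of methyl on a saturated ring carbon of the five-membered non-aromatic ring of compound 1, the carbon next to the ring nitrogen: phenyl in place of methyl on a saturated ring carbon. Among the measured compounds shown here, no measured pair shows a change at this place, so the expectation rests on the structural change alone and is uncertain. A modest step to a lower number in this assay is expected, and a result within the scatter would not be surprising. The expected change is a 1.8-fold lower number from compound 1 to compound 3 (0.26 log units; within the scatter). For compound 3 the estimated value is 3500 nM, with an expected range of 900 nM to 12000 nM.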

Compound 3, half-maximal inhibitory concentration: 15300 nM
Compound 3: middle estimate off by 4.4-fold (0.64 log units), on the low side; the whole stated range lies below it.
By their numbers in this assay, from the lowest: compound 2; then compound 1; then compound 3.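

In this assay, the saturated ring carbon next to the ring nitrogen now has its first measured step: phenyl in place of methyl gives a 2.4-fold higher number from compound 1 to compound 3 (0.38 log units; beyond the scatter), a modest change but one beyond the scatter. This position therefore responds to the choice of group, and here the larger aromatic ring moves the number in the weaker direction, against the small gain that was expected. No measurement shown explains the direction of this step.

With only methyl and phenyl shown at this carbon, two points cannot be separated: whether the rise follows the number of heavy atoms added or the presence of an aromatic ring. An ethyl or cyclohexyl group at this carbon would help to separate them, and a hydrogen there would show what methyl itself contributes.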